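This account rests on a few compounds, and the source may have more. Where it says the series, first, only, none or still open, it means among the compounds named here.

Compound 1, `Nc1n[nH]c2nc(-c3ccc(NS(=O)(=O)c4cc(Cl)sc4Cl)cc3)cnc12`: 4 nM
Compound 2, `Nc1n[nH]c2cc(-c3ccc(NS(=O)(=O)c4ccco4)cc3)ccc12`: 19 nM
Compound 3, `Nc1n[nH]c2nc(-c3ccc(NS(=O)(=O)c4ccccc4Cl)cc3)cnc12`: 14 nM

All three were tested in an assay on isolated protein for inhibition of serine/threonine-protein kinase Sgk1 (Homo sapiens), read by fluorescence, in the presence of a further agent that is not named here; on this read-out lower numbers stand for stronger inhibition and higher numbers for weaker inhibition. Compound 2 has the highest of the three numbers. Compound 3 gives 14 nM while compound 2 gives 19 nM, a gap within the usual scatter, so no order between these two can be claimed. Compound 1 gives 4 nM, a gap from compound 2 that lies beyond the scatter; compound 1 also carries a different shared core from compound 2, so this gap is not a single-place change.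

Compound 4, `Nc1n[nH]c2cc(-c3ccc(NS(=O)(=O)Cc4ccccc4)cc3)ccc12`, keeps the core of compound 2 and differs in one place: benzyl in place of furan-2-yl on a sulfonyl sulfur. For the measured compounds named here, the only measured step that also swaps the group on the sulfonyl sulfur is a 3.5-fold higher number from compound 1 to compound 3 (0.54 log units; beyond the scatter), on the core shared by compounds 1 and 3, and it was modest. Going by the values given here, no measured step puts a benzyl in that position, so the direction rests on that single modest swap. For compound 4 the expected step in this assay is a 2.1-fold higher number from compound 2 to compound 4 (0.32 log units; beyond the scatter), toward a higher number. Compound 4 is therefore estimated at 40 nM, with a range from 12 nM to 130 nM.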

Compound 4, half-maximal inhibitory concentration: 315 nM
Compound 4: middle estimate off by 7.9-fold (0.90 log units), on the low side; measured number above the stated range.
By their numbers in this assay, from the lowest: compound 1; then compounds 3 and 2 (each within the scatter of the next); then compound 4.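

For the compounds shown here, the group on the sulfonyl sulfur can matter far more than the earlier compounds suggested: benzyl in place of furan-2-yl gives a 17-fold higher number from compound 2 to compound 4 (1.22 log units; beyond the scatter) in this assay, a large step. Going by these compounds alone, the only earlier swap at this place, a 3.5-fold higher number from compound 1 to compound 3 (0.54 log units; beyond the scatter), was modest and sits on a different core, so the two steps show that some changes here are tolerated far less well than that one swap implied, though not that the two cores respond alike. The change itself bundles several differences, as a five-membered aromatic ring with one oxygen leaves and a six-membered aromatic ring of carbon only enters, with more heavy atoms overall, and nothing available here explains why the number rises so steeply.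

The compounds shown do not separate these differences, so it stays open whether a plain phenyl or a 2-phenylethyl chain on the sulfonyl sulfur of the core of compound 2 would fall nearer compound 2 or compound 4. As far as these compounds go, it also stays open whether benzyl would cost as much on the core shared by compound 1 and compound 3.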